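The source may hold more compounds than are shown below. What is called first, only, known or untested is meant among the compounds shown, and "the series" means these compounds.

Measured in an assay on CHO-K1 cells for displacement of a labelled ligand from prostaglandin E2 receptor EP1 subtype (Homo sapiens); on this read-out lower numbers stand for stronger inhibition and higher numbers for weaker inhibition:
- compound 1, `Cc1cc(C(=O)NC(C)C)nn1Cc1cc(Cl)ccc1OCc1ccccc1`: 126 nM
- compound 2, `Cc1cc(C(=O)NCc2cccnc2)nn1Cc1cc(Cl)ccc1OCc1ccccc1`: 50.1 nM
- compound 3, `CC(=O)Nc1cc(C)n(Cc2cc(Cl)ccc2OCc2ccccc2)n1`: 316 nM

Compound 1 holds the second highest of the three numbers. Its nearest neighbour is compound 3, a 2.5-fold higher number from compound 1 to compound 3 (0.40 log units; beyond the scatter); the furthest is compound 2, a 2.5-fold lower number from compound 1 to compound 2 (0.40 log units; beyond the scatter). The longer step in the set, a 6.3-fold higher number from compound 2 to compound 3 (0.80 log units; beyond the scatter), links those two ends.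

The next compound, compound 4, `Cc1cc(NC(=O)OCc2ccccn2)nn1Cc1cc(Cl)ccc1OCc1ccccc1`, differs from compound 1 in one place: (((pyridin-2-yl)methoxy)carbonyl)amino in place of isopropylcarbamoyl on an aromatic carbon.

Among the compounds with values here, two measured steps bear on this change. Compound 3 and compound 4 both carry an amino-type group (acetamido, (((pyridin-2-yl)methoxy)carbonyl)amino) where compound 1 carries isopropylcarbamoyl, and that swap gave a 2.5-fold higher number from compound 1 to compound 3 (0.40 log units; beyond the scatter). Compound 2 and compound 4 both carry a pyridinylmethyl unit on the side group, and that addition gave a 2.5-fold lower number from compound 1 to compound 2 (0.40 log units; beyond the scatter). Within the data shown here, no measured step combines both features, and no carbamate is in the set. If the two tendencies roughly offset, compound 4 is expected to land close to compound 1, so the step of a 1.2-fold higher number from compound 1 to compound 4 (0.08 log units; within the scatter) is expected to stay within the scatter, with the range left wide to cover either tendency dominating. Compound 4 is estimated at 150 nM, between 50 nM and 450 nM.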

Compound 4, half-maximal inhibitory concentration: 79.4 nM
Beside the measured number, compound 4's estimate is 1.9-fold (0.28 log units) above it; the measured number falls inside the stated range.
By their numbers in this assay, from the lowest: compounds 2, 4 and 1 (each within the scatter of the next, the first and the last beyond it); then compound 3.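

With (((pyridin-2-yl)methoxy)carbonyl)amino on this aromatic carbon, the number in this assay stays level with those of both carbamoyl-bearing compounds (a 1.6-fold lower number from compound 1 to compound 4 (0.20 log units; within the scatter); a 1.6-fold higher number from compound 2 to compound 4 (0.20 log units; within the scatter)). The weaker number of the acetamido compound therefore does not follow from the amino-type attachment alone: with that attachment kept, (pyridin-2-yl)methoxy in place of methyl on the carbonyl carbon gives a step beyond the scatter (a 4.0-fold lower number from compound 3 to compound 4 (0.60 log units; beyond the scatter)), so the group on the far side of the carbonyl also counts at this position. No measurement on hand accounts for these steps.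

As far as these compounds go, what the pyridine ring itself contributes remains open, since a benzyloxycarbonylamino group would be needed to separate the ring nitrogen from the aromatic ring, and pyridin-3-yl and pyridin-4-yl versions of the carbamate would show whether the ring nitrogen's place matters. Also open, from the compounds shown here alone, is how far the link can vary, as a urea in place of the carbamate, or a longer chain between the carbonyl and the pyridine ring, would test whether the level seen here holds beyond this one group.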